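The source may hold more compounds than are shown below. What is called first, only, known or untested is meant among the compounds shown, and "the series" means these compounds.

Measured compounds in a functional assay on HL-60 cells (Homo sapiens) for cytotoxicity, read by MTT assay, with a stated time of 24 h; a higher number here means a weaker inhibitor, a lower number a stronger inhibitor:

Compound 1 `CC(C)(C)c1ccc(-c2nnc(SCCCN3CCN(c4ccccc4)CC3)[nH]2)cc1` gives > 300000 nM, which is a limit of the assay and not a number.
Compound 2 `Cc1ccc(-c2nnc(SCCCN3CCN(c4cccc(Cl)c4)CC3)[nH]2)cc1` gives > 300000 nM, again a limit of the assay.
Compound 3 `CCN1CCN(CCCSc2nnc(-c3ccc(C)cc3)[nH]2)CC1` gives > 300000 nM, again a limit of the assay.

Compound 1 stands at the limit of this assay, with no number to place it against the other two; the same holds for compound 2 and for compound 3, so that the limit of > 300000 nM in this assay, at which 3 of the 3 values shown sit, is all the series has given. Within the data shown here, the only step between measured compounds that differ in one place, ethyl in place of 3-chlorophenyl on an amine nitrogen in a ring, is a step that the two limits leave unreadable from compound 2 to compound 3; it lies at a different place from the change considered here and gives no readable size.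

Compound 4 `Cc1cccc(-c2nnc(SCCCN3CCN(c4ccccc4)CC3)[nH]2)c1` is the unmeasured member. It differs from compound 1 by 3-methylphenyl in place of 4-(tert-butyl)phenyl on an aromatic carbon. No measured step bears on this change, and nothing in the shown values points away from the limit in this assay. The expected step from compound 1 to compound 4 is therefore a number no higher from compound 1 to compound 4 (the limit leaves the size open), meaning no shift beyond the scatter and most likely a value again reported as a limit. Compound 4 is estimated at 300000 nM, within 100000 nM to 1000000 nM, in this assay.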

Compound 4, half-maximal inhibitory concentration: > 300000 nM
Compound 4: no number, only a limit; the forecaster's own chance of this, stated with the estimate: 85%; the middle value sits exactly at the limit.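

In this assay compound 4 gives > 300000 nM, a limit of the assay and not a number. No step can be read between compound 1 and compound 4, and the series offers one shared result: the limit of > 300000 nM in this assay, at which 4 of the 4 values shown sit. The compounds shown leave open which structural change, if any, would give a measured number in this assay.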